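Lengthening the Hydroxamate Chain in a Propargylamine Series

The source may report more compounds than this note shows. Statements on the series, on what has been measured and on what is new or still open speak of the compounds shown alone.

Three compounds share one core and differ only in the length of the chain that carries the hydroxycarbamoyl group. Compound 1, `C#CCN(C)Cc1ccc(NC(=O)CCC(=O)NO)cc1`, sits at the limit of a functional assay on PC-3 cells (Homo sapiens) for inhibition, read by MTT assay, with a stated time of 48 h; a lower number here means a stronger inhibitor of growth, a higher number a weaker inhibitor of growth: compound 1 gives > 10000 nM, a limit of the assay rather than a number. Compound 2, `C#CCN(C)Cc1ccc(NC(=O)CCCC(=O)NO)cc1`, likewise gives > 10000 nM in this assay, again a limit. Compound 3, `C#CCN(C)Cc1ccc(NC(=O)CCCCCC(=O)NO)cc1`, gives > 10000 nM in this assay, also a limit and not a measured number. The steps a step that the two limits leave unreadable from compound 1 to compound 2, a step that the two limits leave unreadable from compound 1 to compound 3 and a step that the two limits leave unreadable from compound 2 to compound 3 therefore cannot be read in size or direction, since all three values sit together at the limit of > 10000 nM in this assay, at which 3 of the 3 values shown sit.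

Compound 4, `C#CCN(C)Cc1ccc(NC(=O)CCCCCCC(=O)NO)cc1`, differs from compound 3 by (hydroxycarbamoyl)methyl in place of hydroxycarbamoyl on a saturated chain carbon, five bonds along the chain from a carbonyl carbon. Within the data shown here, no measured step is readable, so nothing in the numbers so far marks a direction for this change, and the three limits give no sign that one more chain carbon brings the series into the measurable range. On that footing compound 4 is expected to remain at the same limit, with a step that the limit leaves unreadable from compound 3 to compound 4 as the estimated step and an estimated value of 15000 nM, between 5000 nM and 50000 nM.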

Compound 4, concentration for 50% growth inhibition: 2280 nM
The estimate for compound 4 lay 6.6-fold (0.82 log units) above the measured number; measured number below the stated range.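

Among these compounds, at this position, five bonds along the chain from a carbonyl carbon, (hydroxycarbamoyl)methyl in place of hydroxycarbamoyl gives an at least 4.3-fold lower number from compound 3 to compound 4 (0.64 log units; beyond the scatter) in this assay, the first change whose direction can be read. The two shorter chains give the same reading, with an at least 4.3-fold lower number from compound 2 to compound 4 (0.64 log units; beyond the scatter) and with an at least 4.3-fold lower number from compound 1 to compound 4 (0.64 log units; beyond the scatter) as well, so compound 4 stands apart from all three earlier compounds, whose mutual steps still cannot be read. Each of these three new steps is a bound and not a full size, as the number for compound 4 is set against a limit, and the true gaps could be larger; the series therefore shows a single measured number at the end of a run of limits: the limit of > 10000 nM in this assay, at which 3 of the 4 values shown sit.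

The compounds shown leave open whether a longer chain than that of compound 4 would lower the number further, hold it steady or raise it again. They also leave open how far the measured growth inhibition depends on the propargyl amine or on the hydroxamic acid, which could be tested by setting a different amine or a carboxylic acid on the same chain.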